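Adding one methyl to compound 2

This account rests on a few compounds, and the source may have more. Where it says the series, first, only, none or still open, it means among the compounds named here.

compound 1 `Cc1ccc2nc(NC(c3cn(-c4ccccc4)nc3-c3cccc([N+](=O)[O-])c3)c3c(O)ccc4ccccc34)sc2c1`: 38400 nM
compound 2 `O=[N+]([O-])c1ccc(-c2nn(-c3ccccc3)cc2C(Nc2nc3ccccc3s2)c2c(O)ccc3ccccc23)cc1`: 14700 nM

In a functional assay on MCF7 cells (Homo sapiens) for antiproliferative activity, read by MTT assay, with a stated time of 48 h (a lower number here means a stronger inhibitor, a higher number a weaker inhibitor), compound 2 gives the lower of the two numbers, 14700 nM, while compound 1 stands at 38400 nM, a gap beyond the usual scatter of repeat measurements.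

Compound 3 `Cc1ccc2nc(NC(c3cn(-c4ccccc4)nc3-c3ccc([N+](=O)[O-])cc3)c3c(O)ccc4ccccc34)sc2c1` is compound 2 with one small edit: methyl in place of hydrogen on an aromatic carbon. The 1,3-benzothiazol-2-yl group becomes 6-methyl-1,3-benzothiazol-2-yl, with methyl in place of hydrogen on an aromatic carbon. For the measured compounds named here, no measured pair shows this edit alone, so the data give no direct guide to its size. For so small an edit, no step beyond the scatter is expected in this assay, and the estimate starts from compound 2 at 14700 nM. The expected change is slight, a 1.2-fold higher number from compound 2 to compound 3 (0.09 log units; within the scatter). Compound 3 is estimated at 18000 nM, within a range of 7000 nM to 45000 nM.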

Compound 3, half-maximal inhibitory concentration: 20700 nM
Compound 3: the middle estimate sits 1.2-fold (0.06 log units) below what was measured; measured number inside the range.
By their numbers in this assay, from the lowest: compounds 2, 3 and 1 (each within the scatter of the next, the first and the last beyond it).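

Placing a methyl on the 1,3-benzothiazol-2-yl group gives a 1.4-fold higher number from compound 2 to compound 3 (0.15 log units; within the scatter) in this assay, so this position accepts the methyl with no step that can be told apart from repeat-measurement noise. For the compounds shown here, exchanging 3-nitrophenyl for 4-nitrophenyl gives a 1.9-fold lower number from compound 1 to compound 3 (0.27 log units; within the scatter) and is the first view of that change alone, which also stays inside the scatter, so neither single edit shows a clear effect of its own. Nothing measured alongside these numbers offers an explanation for either step.

Going by these compounds, whether a larger group at the same aromatic carbon, such as methoxy, an amine or a longer chain, would give a step beyond the scatter remains open. So does what happens when the nitro group itself gives way to a nitrile or a carboxylic acid.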